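This account rests on a few compounds, and the source may have more. Where it says the series, first, only, none or still open, it means among the compounds named here.

Compound 3 `Cc1cc(C)c(CN2CCc3c(Cl)cc([C@H](CO)[C@@H]4CCCO4)c(Cl)c3C2=O)c(=O)[nH]1` gives 10 nM in an assay for inhibition of histone-lysine N-methyltransferase EZH2 variant Y641N (Homo sapiens), read by scintillation counting, with a stated time of 60 min, in the presence of a further agent that is not named here (a lower number here means a stronger inhibitor, a higher number a weaker inhibitor), the higher of the two single numbers in hand for this series. For the measured compounds named here, compound 1 `Cc1cc(C)c(CN2CCc3c(Cl)cc([C@H](CO)[C@H]4CCOC4)c(Cl)c3C2=O)c(=O)[nH]1` gives 0.24 nM in this assay, and the step of a 42-fold higher number from compound 1 to compound 3 (1.62 log units; beyond the scatter) is the only one-place change measured so far. Compound 2 `COC(c1cc(Cl)c2c(c1Cl)C(=O)N(Cc1c(C)cc(C)[nH]c1=O)CC2)C1CCOCC1` gives 310 nM; 0.1 nM (2 entries) in this assay; its entries disagree widely with each other, as the several entries of compound 2 in this assay, 310 nM; 0.1 nM (2 entries) shows, so it sets no single reference point.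

Compound 4 `Cc1cc(C)c(CN2CCc3c(Cl)cc([C@H](C)CO)c(Cl)c3C2=O)c(=O)[nH]1` differs from compound 3 by a group of 4 heavy atoms (3 carbon, 1 oxygen; no ring) in place of a group of 8 heavy atoms (6 carbon, 2 oxygen; one five-membered non-aromatic ring with 1 hetero atom), on an aromatic carbon. Going by the values given here, no measured step removes the ring from this position. The step of a 42-fold higher number from compound 1 to compound 3 (1.62 log units; beyond the scatter) shows only that moving the attachment point of the five-membered ring shifts the number in this assay far beyond the scatter, so the outcome at this position depends strongly on what sits there. The spread of compound 2 gives no direction either way. For compound 4 the expectation is a moderate loss on reducing the group to 1-(hydroxymethyl)ethyl, with a 4.0-fold higher number from compound 3 to compound 4 (0.60 log units; beyond the scatter) expected, while the uncertainty around compound 2 keeps the range wide. Compound 4 is therefore estimated at 40 nM in this assay, between 5 nM and 300 nM.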

Compound 4, inhibition constant: 17 nM
The estimate for compound 4 lay 2.4-fold (0.37 log units) above the measured number; the measured number falls inside the stated range.
By their numbers in this assay, from the lowest: compound 1; then compounds 3 and 4 (each within the scatter of the next).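

At this position, on an aromatic carbon ortho to a chloro group, exchanging the group bearing the five-membered ring for 1-(hydroxymethyl)ethyl gives a 1.7-fold higher number from compound 3 to compound 4 (0.23 log units; within the scatter) in this assay and so costs nothing measurable when the oxolan-2-yl group is the reference. The same exchange gives a 71-fold higher number from compound 1 to compound 4 (1.85 log units; beyond the scatter) when the oxolan-3-yl group is the reference, so the presence of a ring alone does not set the number. Among these three compounds only the oxolan-3-yl attachment stands apart: compound 1 gives 0.24 nM in this assay while the oxolan-2-yl ring of compound 3 holds no advantage beyond the scatter over the open chain of compound 4.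

Still open, from the compounds shown here alone, is whether the low number of compound 1 follows the position of the ring oxygen or the stereocentre at the ring carbon, and how an amine or a carboxylic acid in place of the hydroxyl of the 1-(hydroxymethyl)ethyl group would read in this assay on the shared core. Nothing in the evidence at hand accounts for these steps.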